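Bromo for hydrogen across two cores in a cytotoxicity series

This account rests on a few compounds, and the source may have more. Where it says the series, first, only, none or still open, it means among the compounds named here.

Compound 1 `COc1ccc(C2CC(c3ccccc3)=NN2C2=NC(=O)/C(=C3\C(=O)Nc4ccccc43)S2)cc1` is the parent of the first pair. In a functional assay on cells (Cancer cell lines, Homo sapiens) for cytotoxicity, read by sulforhodamine B assay, with a stated time of 48 h (on this read-out higher numbers stand for weaker inhibition of growth and lower numbers for stronger inhibition of growth), compound 1 gives 19000 nM. Compound 2 `COc1ccc(C2CC(c3ccccc3)=NN2C2=NC(=O)/C(=C3\C(=O)Nc4ccc(Br)cc43)S2)cc1` carries the change bromo in place of hydrogen on an aromatic carbon and in this assay compound 2 gives 3630 nM, so the step of a 5.2-fold lower number from compound 1 to compound 2 (0.72 log units; beyond the scatter) is the one reference for what this change does.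

Compound 3 `COc1ccc(C2=NN(C3=NC(=O)/C(=C4\C(=O)Nc5ccccc54)S3)C(c3ccc(Cl)cc3)C2)cc1` belongs to a second core; the difference between the two cores is not broken down here. In this assay compound 3 gives 100000 nM, the highest number of the three measured compounds. Compound 4 `COc1ccc(C2=NN(C3=NC(=O)/C(=C4\C(=O)Nc5ccc(Br)cc54)S3)C(c3ccc(Cl)cc3)C2)cc1` is not yet measured and differs from compound 3 by bromo in place of hydrogen on an aromatic carbon. The place of the change is described in the same words as for the first pair, so it is the same change, now made on the second core.

Among the measured compounds shown here, the expectation for compound 4 rests on compound 2, whose step a 5.2-fold lower number from compound 1 to compound 2 (0.72 log units; beyond the scatter) is the only measured instance of this change. Compound 4 is expected to show a step of a 4.0-fold lower number from compound 3 to compound 4 (0.60 log units; beyond the scatter) in this assay, a move of the same kind as for compound 2 but held a little more cautiously because compound 3 starts from 100000 nM, a number that may sit near the edge of what the assay reports. The estimate for compound 4 in this assay is 25000 nM, with a likely range from 8000 nM to 100000 nM.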

Compound 4, concentration for total growth inhibition: 14700 nM
The estimate for compound 4 lay 1.7-fold (0.23 log units) above the measured number; the range from low to high includes it.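

In this assay bromo in place of hydrogen on an aromatic carbon gives a 6.8-fold lower number from compound 3 to compound 4 (0.83 log units; beyond the scatter), so on the core of compound 3 the change moves the number in the same direction as it does on the core of compound 1. Among the compounds shown here, the two steps also match in size, with no difference that stands out from the usual scatter of such measurements: the same change on two cores in this assay, a 5.2-fold lower number (0.72 log units; beyond the scatter) from compound 1 to compound 2 and a 6.8-fold lower number (0.83 log units; beyond the scatter) from compound 3 to compound 4, 1.3-fold (0.11 log units) apart, within the scatter of two such steps This shows that, within this series and in this read-out, the change carried from one core to the other with its effect intact, but the evidence is only two matched pairs with the bromo at one ring place, and it does not show that the change would carry to any further core, nor does it say why the number falls.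

The compounds shown leave open whether this step belongs to bromo in particular or would also appear with fluoro, a nitrile or an amine on the same aromatic carbon. They also leave open whether the step would hold on a core where a carboxylic acid or a longer chain takes the place of the chloro group of compound 3.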